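The source may report more compounds than this note shows. Statements on the series, on what has been measured and on what is new or still open speak of the compounds shown alone.

Measured compounds:
Compound 1 `O/N=C(/Nc1cccc(Cl)c1)c1ccc2occc2c1`; in an assay on isolated protein for inhibition of Indoleamine 2,3-dioxygenase 1 (Homo sapiens), read by spectrophotometry (on this read-out higher numbers stand for weaker inhibition and lower numbers for stronger inhibition), compound 1 gives 690 nM.
Compound 2 `CC(=O)c1cccc(N/C(=N/O)c2ccc3occc3c2)c1`; in this assay compound 2 gives > 30000 nM, which is a limit of the assay and not a number.

Compound 2 therefore stands at the weak end of what has been measured, sitting at the limit (the limit of > 30000 nM in this assay, at which 1 of the 2 values shown sits). Going by the values given here, the one measured step, an at least 43-fold higher number from compound 1 to compound 2 (1.63 log units; beyond the scatter), is a large loss when acetyl replaces chloro. Compound 3 `CCCCOc1cccc(N/C(=N/O)c2ccc3occc3c2)c1` carries the change (butoxy in place of acetyl on an aromatic carbon). Among the compounds with values here, no measured step involves butoxy, so the step from compound 1 to compound 2 bears on it only by showing that acetyl is far weaker than chloro at this position; how butoxy compares is not known from these compounds. The step from compound 2 to compound 3 is expected to be a recovery, an at least 6.0-fold lower number from compound 2 to compound 3 (0.77 log units; beyond the scatter), toward the value of compound 1 without reaching it. Compound 3 is estimated at 5000 nM, within a range from 800 nM to 30000 nM.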

Compound 3, half-maximal inhibitory concentration: > 30000 nM
Compound 3: no number, only a limit (the forecaster's own chance of this, stated with the estimate: 30%); at least 6.0-fold (0.77 log units) between middle value and limit.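

In this assay compound 3 gives > 30000 nM, which is a limit of the assay and not a number. Butoxy in place of chloro is a large loss, an at least 43-fold higher number from compound 1 to compound 3 (1.63 log units; beyond the scatter), so acetyl is no longer the only group on this aromatic carbon that fails to keep the activity of compound 1. The step from compound 2 to compound 3 cannot be read, and acetyl and butoxy stay unranked, as both compounds sit at the same ceiling: the limit of > 30000 nM in this assay, at which 2 of the 3 values shown sit.

The compounds shown leave open whether chloro is unusual at this position or whether other small groups, such as fluoro, methyl or an amine, also give a readable value. They also leave open whether a shorter alkoxy chain, such as methoxy, would do so where butoxy does not.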